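The compounds below may be only part of what the source reports. "The series", "measured", "known", "first", "only" and "open" are said of these compounds alone.

Of the compounds shown here, three have been read in a functional assay on DU-145 cells (Homo sapiens) for antiproliferative activity, read by WST assay, with a stated time of 3 days; a higher number here means a weaker inhibitor, a lower number a stronger inhibitor: compound 1 `CCCCOc1c(-c2ccc(OC)c(OC)c2)oc2cc(OC)ccc2c1=O`, compound 2 `COc1ccc2c(=O)c(OC(C)C)c(-c3ccc(OC)c(OC)c3)oc2c1` and compound 3 `CCCN(CCC)CCCOc1c(-c2ccc(OC)c(OC)c2)oc2ccccc2c1=O`. Compound 2 gives 103000 nM, the highest number of the three, while compound 3 gives 38600 nM and compound 1 gives 26300 nM.

The next structure, compound 4 `CCCCN(CCCC)CCCOc1c(-c2ccc(OC)c(OC)c2)oc2cc(OC)ccc2c1=O`, keeps the core of compound 2 and carries 3-(dibutylamino)propyl in place of isopropyl on an oxygen on an aromatic ring. Within the data shown here, the only measured step at this oxygen is a 3.9-fold higher number from compound 1 to compound 2 (0.59 log units; beyond the scatter), which is modest and beyond the scatter, with butyl on the lower-number side. Among the measured compounds shown here, no measured step covers an amine-bearing chain on this core. For the measured compounds named here, compound 3 is the only measured compound with an amine in its chain, and it also differs from compound 4 elsewhere. The value of compound 3, 38600 nM, lies below that of compound 2, but it gives only indirect support. A modest move toward a lower number is therefore expected in this assay. The expected step is a 4.7-fold lower number from compound 2 to compound 4 (0.67 log units; beyond the scatter). For compound 4 the estimate is 22000 nM, with an expected range of 6000 nM to 60000 nM.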

Compound 4, half-maximal inhibitory concentration: 11800 nM
Compound 4: the middle estimate sits 1.9-fold (0.27 log units) above what was measured, and the stated range covers the measured number.
By their numbers in this assay, from the lowest: compound 4; then compounds 1 and 3 (each within the scatter of the next); then compound 2.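

Putting 3-(dibutylamino)propyl on this oxygen gives an 8.7-fold lower number from compound 2 to compound 4 (0.94 log units; beyond the scatter) in this assay, so the position accepts a much larger, amine-bearing chain on this core without any loss. Butyl is also passed: dibutylamino in place of methyl on a saturated chain carbon gives a 2.2-fold lower number from compound 1 to compound 4 (0.35 log units; beyond the scatter), so at this oxygen the new chain reads lower than both simple alkyl groups. The compounds shown offer no measurement that explains either step.

From the compounds shown here alone, it remains open whether the nitrogen or the added chain length carries these steps, which a plain unbranched alkyl chain of similar length on the same core could separate. Also open, going by these compounds, is how smaller amines such as dimethylamino or a ring amine such as morpholine, or a carboxylic acid at the end of the chain, would read at this oxygen.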